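Swapping the difluorophenyl for methylphenyl in a ghrelin antagonist

The compounds below may be only part of what the source reports. "The series", "measured", "known", "first", "only" and "open" are said of these compounds alone.

Measured compounds:
compound 1, `CC(C)(N)C(=O)N[C@H](COCc1ccc(F)cc1F)c1nnnn1CCOC(=O)NCCCCO`, 0.42 nM
compound 2, `CC(C)(N)C(=O)N[C@H](COCc1ccccc1Cl)c1nnnn1CCOC(=O)NCCCCO`, 0.45 nM
compound 3, `CC(C)(N)C(=O)N[C@H](COCc1cccc(Cl)c1)c1nnnn1CCOC(=O)NCCCCO`, 1.6 nM

In a functional assay on cells for inhibition of growth hormone secretagogue receptor type 1 (Homo sapiens), read by FLIPR and calcium flux (on this read-out lower numbers stand for an effect already at smaller amounts and higher numbers for an effect only at larger amounts of compound), compound 1 has the lowest number of the three, though compound 2 sits within the scatter of it. Going by the values given here, compound 4 is `Cc1ccccc1COC[C@@H](NC(=O)C(C)(C)N)c1nnnn1CCOC(=O)NCCCCO`; its only change from compound 1 is 2-methylphenyl in place of 2,4-difluorophenyl on a saturated chain carbon bound to an oxygen on a saturated carbon. Among the compounds with values here, two measured steps bear on this: a 1.1-fold higher number from compound 1 to compound 2 (0.03 log units; within the scatter), where another singly substituted phenyl replaced the 2,4-difluorophenyl, and a 3.8-fold higher number from compound 1 to compound 3 (0.58 log units; beyond the scatter). The 2-methylphenyl resembles the 2-chlorophenyl of compound 2 more than the 3-chlorophenyl of compound 3, so a step of about a 1.4-fold higher number from compound 1 to compound 4 (0.15 log units; within the scatter) is expected, not clearly beyond the scatter. Compound 4 is therefore estimated at 0.6 nM, in a range from 0.25 nM to 1.5 nM.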

Compound 4, half-maximal effective concentration: 0.51 nM
Compound 4: middle estimate off by 1.2-fold (0.07 log units), on the high side; the measured number falls inside the stated range.
By their numbers in this assay, from the lowest: compounds 1, 2 and 4 (each within the scatter of the next); then compound 3.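

In this assay, 2-methylphenyl on this saturated chain carbon gives a 1.2-fold higher number from compound 1 to compound 4 (0.08 log units; within the scatter) and a 1.1-fold higher number from compound 2 to compound 4 (0.05 log units; within the scatter), so a methyl group, with no halogen on the ring, serves here like the fluorines of compound 1 and the chloro of compound 2. Set against the 3-chlorophenyl, the same group gives a 3.1-fold lower number from compound 3 to compound 4 (0.50 log units; beyond the scatter), which leaves compound 3 as the only one of the four set apart by its number.

As far as these compounds go, whether a 3-methylphenyl, or a ring carrying an amine or a carboxylic acid, would fit as well stays open. Nothing shown gives a measured reason for these numbers.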